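A Bromo Substituent Tried on Two Related Cores

This account rests on a few compounds, and the source may have more. Where it says the series, first, only, none or still open, it means among the compounds named here.

Measured so far:
Compound 1, `CCCn1cnc2c(N)nc(NCc3ccccc3)nc21`, in a functional assay on CHO cells for antagonist activity at adenosine receptor A2b (Homo sapiens); a higher number here means a weaker inhibitor, a lower number a stronger inhibitor: > 30000 nM (a limit of the assay)
Compound 2, `CCCn1c(Br)nc2c(N)nc(NCc3ccccc3)nc21`, in this assay: 1740 nM
Compound 3, `CCCn1cnc2c(NCCCc3ccccc3)ncnc21`, in this assay: > 30000 nM (a limit of the assay)

Compound 1 and compound 2 share one core and differ in a single place. For compound 1 the result in this assay is a limit of the assay, > 30000 nM. Compound 2 gives 1740 nM. The change behind this is bromo in place of hydrogen on an aromatic carbon, and it made an at least 17-fold lower number from compound 1 to compound 2 (1.23 log units; beyond the scatter). How far that step truly reaches is open at one end due to the limit of > 30000 nM in this assay, at which 2 of the 3 values shown sit.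

Compound 3 rests on a different core; the difference between the two cores is not broken down here. For compound 3 the result in this assay is again a limit of the assay, > 30000 nM. Compound 4, `CCCn1c(Br)nc2c(NCCCc3ccccc3)ncnc21`, has not been measured. It carries the same change as before, (bromo in place of hydrogen on an aromatic carbon), at the same place on its core.

Resting on the earlier step of an at least 17-fold lower number from compound 1 to compound 2 (1.23 log units; beyond the scatter), the expected step is an at least 5.0-fold lower number from compound 3 to compound 4 (0.69 log units; beyond the scatter). Since the starting point of compound 3 is known only as a limit, the expectation is wide, and a limit may again be all that is reported. For compound 4 the expected value in this assay is 6000 nM, most likely between 1500 nM and 30000 nM.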

Compound 4, inhibition constant: 1760 nM
The estimate for compound 4 lay 3.4-fold (0.53 log units) above the measured number; the range from low to high includes it.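

In this assay, putting bromo in place of hydrogen on an aromatic carbon again gave a large move towards stronger inhibition, an at least 17-fold lower number from compound 3 to compound 4 (1.23 log units; beyond the scatter), so on the two cores shown the change works in the same direction and turns a compound stuck at the limit into one with a real number. The result for compound 3 is only a limit of the assay, > 30000 nM. This shows that the direction of the change carried from the core of compound 1 to the core of compound 3, but it does not show that the change has the same size on both cores: the same change on two cores in this assay, an at least 17-fold lower number (1.23 log units; beyond the scatter) from compound 1 to compound 2 and an at least 17-fold lower number (1.23 log units; beyond the scatter) from compound 3 to compound 4; the limit leaves it open whether they differ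

The compounds shown leave open whether the effect belongs to bromo in particular or would also appear with another group at this place, such as chloro, a methyl group or an amine, or with a longer chain in place of the propyl group. How large either step truly is also stays unknown, since neither compound without bromo gave a number: the limit of > 30000 nM in this assay, at which 2 of the 4 values shown sit.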